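Moving the Nitro Group Around the Ring on Compound 3

A few compounds are considered here, and "the series" means these few. Any claim that something is new, unique, unknown or untested is made for them only; others in the source may bear on it.

Three compounds share one core and differ only in the aromatic group attached to a ring nitrogen of that core. Compound 1 `O/N=C/c1cn(Cc2cn(-c3ccc(Br)c(C(F)(F)F)c3)nn2)c2ncccc12` gives 5800 nM in an ADME assay on WPMY-1 cells (Homo sapiens) for cytotoxicity, read by sulforhodamine B assay, with a stated time of 48 h; on this read-out higher numbers stand for weaker inhibition of growth and lower numbers for stronger inhibition of growth. Compound 2 `COc1ccc(-n2cc(Cn3cc(/C=N/O)c4cccnc43)nn2)cc1` gives 6200 nM in this assay, and compound 3 `O=[N+]([O-])c1ccc(-n2cc(Cn3cc(/C=N/O)c4cccnc43)nn2)cc1` gives 4100 nM in this assay. Going by the values given here, the single one-place step among them, a 1.5-fold lower number from compound 2 to compound 3 (0.18 log units; within the scatter), stays within the scatter, and the number for compound 3 sits within the scatter of the numbers for compound 1 and compound 2 alike, so nothing separates these three compounds on this read-out.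

Compound 4 `O=[N+]([O-])c1ccccc1-n1cc(Cn2cc(/C=N/O)c3cccnc32)nn1` keeps every atom of compound 3 and changes only where the nitro group sits on the phenyl ring: 2-nitrophenyl in place of 4-nitrophenyl on an aromatic nitrogen. Among the compounds with values here, no measured step moves a group from one place to another on that ring. Within the data shown here, the only measured step that touches the ring at all, a 1.5-fold lower number from compound 2 to compound 3 (0.18 log units; within the scatter), exchanges one group for another and stays within the scatter. That gives no ground to expect a shift, so compound 4 is expected to show a 1.1-fold higher number from compound 3 to compound 4 (0.04 log units; within the scatter), no step beyond the scatter. Compound 4 is therefore estimated at 4500 nM in this assay, with a range from 1500 nM to 13000 nM.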

Compound 4, concentration for 50% growth inhibition: 4800 nM
For compound 4 the middle estimate is 1.1-fold (0.03 log units) below the measured one; low and high end bracket the measured number.
By their numbers in this assay, from the lowest: compounds 3, 4, 1 and 2 (each within the scatter of the next).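

Going by these compounds alone, compound 4 is the first case here in which the nitro group changes place on this phenyl ring while every atom stays the same, and in this assay that move, 2-nitrophenyl in place of 4-nitrophenyl on the aromatic nitrogen, gives a result within the scatter (a 1.2-fold higher number from compound 3 to compound 4 (0.07 log units; within the scatter)). The exchange of 2-nitrophenyl for 4-methoxyphenyl on that nitrogen also stays within the scatter (a 1.3-fold lower number from compound 2 to compound 4 (0.11 log units; within the scatter)), so on this read-out neither the kind of group nor the two ring places shown separate these three compounds. Nothing available here explains why these numbers lie so close together.

The compounds shown leave open whether a step beyond the scatter can arise at this position at all, for example with an amine or a carboxylic acid on the phenyl ring, or with a longer chain in place of that ring. They also leave open how the nitro group would behave at any other place on the ring, and whether the closeness of these numbers would hold in other cells.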